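Chloro to hydrogen on the aryl group of compound 1

The compounds below may be only part of what the source reports. "The series", "measured", "known", "first", "only" and "open" are said of these compounds alone.

Measured so far:
- compound 1 `COc1ccc(-c2ccc(Cl)cc2)c2cc(C(=O)Nc3ccc(Cn4ccnc4)cc3)oc12`: in a functional assay on the whole organism for inhibition, with Mus musculus as the target, at a dose of 10 mg/kg by the oral route (a lower number here means less inhibition, a higher number more inhibition at the dose given (going by the name of the read-out)), compound 1 gives "not determined" (no result reported)
- compound 2 `COc1ccc(-c2ccccc2)c2cc(C(=O)NN3CCOCC3)oc12`: in this assay compound 2 gives 78%

Compound 1 stands nowhere on the numbers shown: in this assay it carries no result, so no value of its own anchors the next step. The one measured point in the series is compound 2, which shares the core and the unsubstituted phenyl but carries a different amide, and which reaches 78% in this assay.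

Compound 3 `COc1ccc(-c2ccccc2)c2cc(C(=O)Nc3ccc(Cn4ccnc4)cc3)oc12` is the compound to be measured. Relative to compound 1 the change is hydrogen in place of chloro on an aromatic carbon. Among the compounds with values here, no step between measured compounds is known for this change; the expectation is a step of modest size in this assay, not clearly beyond the scatter in either direction.

For compound 3 in this assay the estimate is 60%, expected to lie between 25% and 90%.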

Compound 3, a percentage reported as inhibition, in the whole organism at one dose (the size of the read-out at that dose, not a potency): 12%
Compound 3: middle estimate off by 48 percentage points, on the high side; measured number outside the range, below it.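

No step can be read from compound 1 to compound 3: in this assay compound 1 gives "not determined" (no result reported) and compound 3 gives 12%. The compounds shown leave open what 4-chlorophenyl to phenyl does in this assay. No evidence at hand bears on the result for compound 3.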